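Shortening the ortho alkyl group on the pendant ring

A few compounds are considered here, and "the series" means these few. Any claim that something is new, unique, unknown or untested is made for them only; others in the source may bear on it.

Measured compounds:
compound 1 `CCc1ccccc1-c1cc2nc(N)nc(N)c2cc1C` gives 41.1 nM
compound 2 `Cc1cc2c(N)nc(N)nc2cc1-c1ccccc1C(C)C` gives 20.9 nM
compound 3 `CCOc1ccc(-c2cccc(NS(C)(=O)=O)c2)cc1-c1ccc2c(N)nc(N)nc2c1` gives 5.8 nM

These three compounds were tested in an assay on isolated protein for inhibition of Dihydrofolate reductase (Homo sapiens), read by spectrophotometry, using NADPH, with a stated time of 10 min; a lower number here means a stronger inhibitor, a higher number a weaker inhibitor. Among them compound 2 stands second highest; its nearest neighbour is compound 1, whose value is within the scatter of repeated measurements, while compound 3 sits furthest away with a value beyond the scatter.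

Compound 4 `Cc1ccccc1-c1cc2nc(N)nc(N)c2cc1C` has not yet been measured. It differs from compound 2 in one place: methyl in place of isopropyl on an aromatic carbon. For the measured compounds named here, only one measured step bears on this change. Going from compound 1 to compound 2, a methyl was added to the saturated chain carbon bound to an aromatic carbon, turning an ethyl into an isopropyl, and this gave a 2.0-fold lower number from compound 1 to compound 2 (0.29 log units; within the scatter). Cutting the isopropyl of compound 2 back to a methyl runs the same kind of change further in the opposite direction. The expectation for compound 4 is therefore a step of a 2.2-fold higher number from compound 2 to compound 4 (0.33 log units; beyond the scatter), towards a somewhat higher number, but not beyond the scatter. The estimate for compound 4 in this assay is 45 nM, with a range from 18 nM to 115 nM.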

Compound 4, inhibition constant: 95.6 nM
Compound 4: the middle estimate sits 2.1-fold (0.33 log units) below what was measured; the measured number falls inside the stated range.
By their numbers in this assay, from the lowest: compound 3; then compounds 2 and 1 (each within the scatter of the next); then compound 4.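

Cutting the isopropyl back to a methyl on this aromatic carbon gives a 4.6-fold higher number from compound 2 to compound 4 (0.66 log units; beyond the scatter), so a change at this position can move the number beyond the scatter, which the earlier step did not show. Removing a single carbon from the ethyl gives a 2.3-fold higher number from compound 1 to compound 4 (0.37 log units; beyond the scatter), so the ethyl of compound 1 and the isopropyl of compound 2, which lie within the scatter of each other, both stand apart from the methyl of compound 4. Nothing measured here explains why the methyl stands apart.

The compounds shown leave open how a cyclopropyl, a tert-butyl or a methoxy group would read at this place. They also leave open whether the same change would give a step of similar size on a core carrying something other than the methyl shared by these three compounds.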